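From a Methyl to a 2-(Trifluoromethyl)benzyl Ether

A few compounds are considered here, and "the series" means these few. Any claim that something is new, unique, unknown or untested is made for them only; others in the source may bear on it.

Compound 1 `COc1cc(OC)c(-c2coc3cc(OCC=C(C)C)ccc3c2=O)cc1OC` gives 1090 nM in a functional assay on B16 cells (Mus musculus) for antiproliferative activity, read by MTT assay, with a stated time of 24 h; a lower number here means a stronger inhibitor, a higher number a weaker inhibitor; compound 2 `COc1ccc2c(=O)c(-c3cc(OC)c(OC)cc3OC)coc2c1` gives 5200 nM.

For the measured compounds named here, compound 2 therefore holds the highest of the two numbers, and the single measured step, a 4.8-fold higher number from compound 1 to compound 2 (0.68 log units; beyond the scatter), separates it from compound 1. Compound 3 `COc1cc(OC)c(-c2coc3cc(OCc4ccccc4C(F)(F)F)ccc3c2=O)cc1OC` differs from compound 2 by 2-(trifluoromethyl)phenyl in place of hydrogen on a saturated chain carbon bound to an oxygen on an aromatic ring. That step bears directly on the new compound, since both changes sit at the same place: it showed that stripping a group there raised the number, and compound 3 restores a larger group there instead. A lower number for compound 3 is expected because a 4.8-fold higher number from compound 1 to compound 2 (0.68 log units; beyond the scatter) points that way. Compound 3 is estimated at 1100 nM (range 400 nM to 3500 nM), an expected step of a 4.7-fold lower number from compound 2 to compound 3 (0.67 log units; beyond the scatter).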

Compound 3, half-maximal inhibitory concentration: 8550 nM
For compound 3 the middle estimate is 7.8-fold (0.89 log units) below the measured one; the measured number lies above the stated range.
By their numbers in this assay, from the lowest: compound 1; then compounds 2 and 3 (each within the scatter of the next).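

In this assay a group entering at this place does not by itself lower the number: 2-(trifluoromethyl)phenyl in place of hydrogen leaves compound 3 within the scatter of compound 2 (a 1.6-fold higher number from compound 2 to compound 3 (0.22 log units; within the scatter)). The 2-methylprop-1-en-1-yl of compound 1 is thus the only group shown here that sets its compound apart, and the 2-(trifluoromethyl)phenyl does not match it (a 7.8-fold higher number from compound 1 to compound 3 (0.89 log units; beyond the scatter)). No measurement at hand accounts for this difference. Still open, as far as these compounds go, is whether an amine, a carboxylic acid or a longer chain at this place would track compound 1 or compound 2.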